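The compounds below may be only part of what the source reports. "The series", "measured", "known", "first", "only" and "open" are said of these compounds alone.

Measured compounds:
- compound 1, `Cc1ccc(NC(=O)COc2ccc3cc(/C=C4/SC(=O)NC4=O)ccc3c2)cc1`: 1700 nM in an assay on isolated protein for inhibition of histone deacetylase 4 (Homo sapiens), with a stated time of 1 h; a lower number here means a stronger inhibitor, a higher number a weaker inhibitor
- compound 2, `O=C(COc1ccc2cc(/C=C3/SC(=O)NC3=O)ccc2c1)Nc1cccc(Cl)c1`: 3800 nM in this assay

Both compounds share one core and differ only in the ring attached to the amide nitrogen. For the measured compounds named here, the single step between them, a 2.2-fold higher number from compound 1 to compound 2 (0.35 log units; beyond the scatter), is the only movement seen so far, and it leaves compound 2 with the higher of the two numbers, the weaker inhibitor of this pair.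

Compound 3, `O=C(COc1ccc2cc(/C=C3/SC(=O)NC3=O)ccc2c1)Nc1cc(Cl)cc(C(F)(F)F)c1`, keeps the whole of compound 2 and adds one group: trifluoromethyl in place of hydrogen on an aromatic carbon, placed on an aromatic carbon of a six-membered aromatic ring of carbon only, meta to a chloro group. Going by the values given here, no measured step shows what a trifluoromethyl group does on this ring, so the one step known, from compound 1 to compound 2, gives only a loose guide: changes on this ring have so far moved the number by a modest amount. With nothing pointing either way, the expected step of a 1.1-fold higher number from compound 2 to compound 3 (0.02 log units; within the scatter) is one that stays within the scatter. Compound 3 is therefore estimated at 4000 nM, with a range from 1500 nM to 11000 nM.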

Compound 3, half-maximal inhibitory concentration: 4000 nM
The estimate for compound 3 equals the measured number at the digits printed; the measured number falls inside the stated range.
By their numbers in this assay, from the lowest: compound 1; then compounds 2 and 3 (each within the scatter of the next).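

In this assay, adding trifluoromethyl to the 3-chlorophenyl ring, meta to a chloro group, gives a 1.1-fold higher number from compound 2 to compound 3 (0.02 log units; within the scatter), so this position accepts a group of 4 heavy atoms in place of a hydrogen without any change that can be told apart from ordinary scatter. Replacing the 4-methylphenyl ring with the 3-chloro-5-(trifluoromethyl)phenyl ring gives a 2.4-fold higher number from compound 1 to compound 3 (0.37 log units; beyond the scatter), which leaves compound 1 with the lowest number of the three and makes it the strongest inhibitor of this small set. No accompanying measurement offers an explanation for why the added trifluoromethyl group leaves the number unchanged within the scatter.

The three rings shown carry only chloro, trifluoromethyl and methyl groups, so it remains open what an amine or a carboxylic acid on this ring would do, or whether a longer chain in place of the methyl group would move the number. From the compounds shown here alone, it is also open whether a change elsewhere on the shared core would have a larger effect than these modest steps on the ring attached to the amide nitrogen.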